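Hydrogen for hydroxy on the way to compound 3

The source may hold more compounds than are shown below. What is called first, only, known or untested is meant among the compounds shown, and "the series" means these compounds.

Going by the values given here, in a physicochemical assay, read by spectrophotometry, with a stated time of 30 min (a lower number here means that less compound is needed, a higher number that more compound is needed for the effect), compound 2 `O=C1c2c(O)cc(O)cc2O[C@H](c2cccc(O)c2O)[C@H]1O` gives 12500 nM, the only true number so far. Compound 1 `O=C1c2c(O)cc(O)cc2O[C@@H](c2ccccc2O)[C@@H]1O` stands at > 100000 nM, which is a limit of the assay and not a number. Compound 3 `O=C1c2c(O)cc(O)cc2O[C@H](c2ccccc2O)[C@H]1O` carries hydrogen in place of hydroxy on an aromatic carbon, ortho to a hydroxy group and meta to a large group (hydrogen in place of hydroxy on an aromatic carbon). Among the compounds with values here, no measured step shows this change, but a large rise beyond the scatter is expected in this assay, towards more compound needed, given compound 1 at the limit of > 100000 nM in this assay, at which 1 of the 2 values shown sits. The expected step is a 6.4-fold higher number from compound 2 to compound 3 (0.81 log units; beyond the scatter). For compound 3 the estimated value is 80000 nM, within an expected range of 30000 nM to 200000 nM.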

Compound 3, half-maximal effective concentration: > 100000 nM
Compound 3: a limit, no number (the forecaster's own chance of this, stated with the estimate: 60%); at least 1.2-fold (0.09 log units) between middle value and limit.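

Hydrogen in place of hydroxy at this position gives an at least 8.0-fold higher number from compound 2 to compound 3 (0.90 log units; beyond the scatter) in this assay, the only readable step among these compounds. Compound 3 gives > 100000 nM, which is a limit of the assay and not a number. The step from compound 1 to compound 3 cannot be read, which leaves one feature of this pair without a size: the fact that compounds 1 and 3 differ only in the configuration as drawn.

Going by these compounds, whether an amine or a methoxy group at this position would give a true number in this assay stays open. On these data alone, how far compound 3 lies past its limit also stays open.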